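Phenyl for Methyl on the Ether Oxygen: Cytotoxicity Outlook

The source may report more compounds than this note shows. Statements on the series, on what has been measured and on what is new or still open speak of the compounds shown alone.

Measured compounds:
compound 1, `CCOC(=O)c1c(-c2cccc(OC)c2)[nH]c2cc(OC)c(OC)cc2c1=O`, > 22000 nM
compound 2, `CCOC(=O)c1c(-c2cccc(Oc3ccccc3)c2)[nH]c2cc(OC)c(OC)cc2c1=O`, > 22000 nM
compound 3, `CCOC(=O)c1c(-c2cccc(OC)c2)[nH]c2cc(Cl)c(Cl)cc2c1=O`, > 22000 nM

All three compounds were tested in an ADME assay on HEK293 cells (Homo sapiens) for cytotoxicity, read by luminescence, with a stated time of 72 h; on this read-out lower numbers stand for an effect already at smaller amounts and higher numbers for an effect only at larger amounts of compound. For compound 1 the value > 22000 nM is a limit of the assay and not a number. For compound 2 the value > 22000 nM is likewise a limit. For compound 3 the value > 22000 nM is also a limit.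

Compound 2 differs from compound 1 by phenyl in place of methyl on an oxygen on an aromatic ring. The step in this assay, a step that the two limits leave unreadable from compound 1 to compound 2, cannot be read in size, since both ends sit at the same limit, (the limit of > 22000 nM in this assay, at which 3 of the 3 values shown sit).

Compound 3 carries a different core from compound 1; the difference between the two cores is not broken down here. Compound 4, `CCOC(=O)c1c(-c2cccc(Oc3ccccc3)c2)[nH]c2cc(Cl)c(Cl)cc2c1=O`, is not yet measured. It stands to compound 3 as compound 2 stands to compound 1: phenyl in place of methyl on an oxygen on an aromatic ring. The place of the change is the same word for word in both pairs, so it is the same change.

Among the compounds with values here, the expectation for the step from compound 3 to compound 4 in this assay is a step that the limit leaves unreadable from compound 3 to compound 4, resting on the limit of compound 3, > 22000 nM, and on the fact that every value so far, (the limit of > 22000 nM in this assay, at which 3 of the 3 values shown sit), sits at that limit. Compound 4 is therefore expected to give about 35000 nM in this assay, most likely reported again as a limit, with an estimated range from 22000 nM to 120000 nM.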

Compound 4, half-maximal effective concentration: > 22000 nM
Compound 4: no number, only a limit; the forecaster's own chance of this, stated with the estimate: 85%; the middle value lies beyond the limit too.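

In this assay compound 4 gives a limit of the assay and not a number (> 22000 nM). No step can be read from compound 3 to compound 4, since both sit at the same limit: the limit of > 22000 nM in this assay, at which 4 of the 4 values shown sit. The compounds shown leave open whether phenyl in place of methyl changes cytotoxicity at all, for none of them gives a number here.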